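The source may hold more compounds than are shown below. What is called first, only, known or untested is meant among the compounds shown, and "the series" means these compounds.

Measured so far:
- compound 1, `COc1cc2cc(Oc3ccc(NC(=O)Nc4cccc(C(F)(F)F)c4)cc3)c(C)nc2cc1OC`: 6180 nM
- compound 2, `COc1cc2cc(Oc3ccc(NC(=O)Nc4ccc(Cl)c(C(F)(F)F)c4)cc3)c(C)nc2cc1OC`: 4900 nM
- compound 3, `COc1cc2cc(Oc3ccc(NC(=O)Nc4ccc(Cl)c(Cl)c4)cc3)c(C)nc2cc1OC`: not yet measured

In a functional assay on SNB-75 cells (Homo sapiens) for inhibition, read by sulforhodamine B assay, with a stated time of 48 h (on this read-out higher numbers stand for weaker inhibition of growth and lower numbers for stronger inhibition of growth), compound 2 gives the lower of the two numbers recorded, with compound 1 the nearest neighbour; the gap between the two lies within the usual scatter, so the two are not distinguishable on these data. Going by the values given here, the only step measured so far, a 1.3-fold lower number from compound 1 to compound 2 (0.10 log units; within the scatter), concerns a change at a different spot on the same ring and is itself too small to read as a real difference.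

Compound 3 differs from compound 2 by chloro in place of trifluoromethyl on an aromatic carbon. Among the compounds with values here, no measured step repeats this exchange, so the one step recorded can only show that a small change on this ring left the number inside the scatter. The same is therefore expected here: no step beyond the scatter in this assay, in either direction. On that basis compound 3 is expected to give about 4900 nM, with a plausible range from 2000 nM to 12000 nM, which means an expected step of no change at the digits printed from compound 2 to compound 3 (within the scatter).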

Compound 3, concentration for total growth inhibition: 8280 nM
Compound 3: the middle estimate sits 1.7-fold (0.23 log units) below what was measured; low and high end bracket the measured number.
By their numbers in this assay, from the lowest: compounds 2, 1 and 3 (each within the scatter of the next).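

In this assay, putting chloro in place of trifluoromethyl turns the 4-chloro-3-(trifluoromethyl)phenyl group into 3,4-dichlorophenyl and gives a 1.7-fold higher number from compound 2 to compound 3 (0.23 log units; within the scatter). Going by these compounds alone, this is the first direct look at this position, ortho to a chloro group, and it shows that going from a group of 4 heavy atoms to one of 1 heavy atom leaves the number within the usual scatter. Compound 1, which has hydrogen at the place of the second chloro and trifluoromethyl where compound 3 has chloro, gives the same kind of result, with a 1.3-fold higher number from compound 1 to compound 3 (0.13 log units; within the scatter), so the three compounds cannot be told apart in this assay, and no measurement on hand offers an explanation for how close they are.

The compounds shown leave open whether a group of a different kind at this position, such as an amine or a carboxylic acid, would move the number beyond the scatter. On these data alone, it also remains open whether a longer chain there, such as a propyl group, would keep the number in this same range.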